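Swapping an aromatic ring on a shared thiazole-type core

A few compounds are considered here, and "the series" means these few. Any claim that something is new, unique, unknown or untested is made for them only; others in the source may bear on it.

Three compounds sharing the core of compound 1, `Nc1nc(-c2ccc(Cl)cc2)c(CC(=O)O)s1`, have been measured in an in vitro functional assay on HEK285-7 cells for antagonist activity at prostaglandin D2 receptor 2 (Homo sapiens), read by BRET and beta-arrestin recruitment; on this read-out higher numbers stand for larger maximal responses and lower numbers for smaller maximal responses. Compound 1 gives 50%. Compound 2, `COc1cc(-c2nc(C(c3ccc(F)cc3)c3ccc(F)cc3)sc2CC(=O)O)ccn1`, gives 60%, the second highest of the three numbers; compound 1 lies within the usual scatter of it, while compound 3, `COc1ccc(C(c2ccccc2)c2nc(-c3ccc(Cl)cc3)c(CC(=O)O)s2)cc1`, with 80%, sits beyond the scatter above it. The unmeasured compound 4, `O=C(O)Cc1sc(C(c2ccc(F)cc2)c2ccc(F)cc2)nc1-c1cc(F)cc(F)c1`, differs from compound 2 in one place: 3,5-difluorophenyl in place of 2-methoxypyridin-4-yl on an aromatic carbon. Among the compounds with values here, no measured pair isolates this change, so the step from compound 2 to compound 4 in this assay is expected to be small, in no clear direction, and within the scatter. Compound 4 is therefore estimated to reach 60%, with a range from 40% to 80%, and an expected step of no change at the digits printed from compound 2 to compound 4 (within the scatter).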

Compound 4, largest response reached (reported as efficacy), in percent of the reference or control that the assay uses: 80%
Compound 4: middle estimate off by 20 percentage points, on the low side; the measured number falls inside the stated range.
By their numbers in this assay, from the lowest: compounds 1 and 2 (each within the scatter of the next); then compounds 3 and 4 (each within the scatter of the next).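

In this assay, 3,5-difluorophenyl in place of 2-methoxypyridin-4-yl gives a number 20 percentage points higher from compound 2 to compound 4 (beyond the scatter). Within the data shown here, this pair is the first to isolate this position, and it shows that the maximal response depends on which ring sits here, even though both groups are six-membered aromatic rings with 8 heavy atoms. Nothing available explains the shift.

From the compounds shown here alone, the swap changes the ring nitrogen, the methoxy group and the two fluorines together, so which of them matters remains open. A 3-fluorophenyl or 2-methoxyphenyl ring at this place would help separate these parts.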